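Swapping the sulfonamide headgroup: dimethylpyrimidine to thiazole

The compounds below may be only part of what the source reports. "The series", "measured", "known", "first", "only" and "open" are said of these compounds alone.

Measured so far in a functional assay on SF-268 cells (Homo sapiens) for antiproliferative activity, read by sulforhodamine B assay, with a stated time of 72 h; on this read-out lower numbers stand for stronger inhibition and higher numbers for weaker inhibition:
compound 1 `Cc1ccc(C(/C=C/c2ccc(F)cc2)=N\Nc2nncc3ccccc23)cc1` gives 6.5 nM
compound 2 `O=S(=O)(Nc1ccccn1)c1ccc(Nc2nncc3ccccc23)cc1` gives 25 nM
compound 3 `Cc1cc(C)nc(NS(=O)(=O)c2ccc(Nc3nncc4ccccc34)cc2)n1` gives 7.6 nM

Compound 3 has the second number of these three. Compound 1 lies within the usual scatter of compound 3, so the two cannot be ranked against each other; compound 2 is the furthest away, with a higher number that sits beyond the scatter.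

Compound 4 `O=S(=O)(Nc1nccs1)c1ccc(Nc2nncc3ccccc23)cc1` differs from compound 3 in one place: 1,3-thiazol-2-yl in place of 4,6-dimethylpyrimidin-2-yl on a sulfonamide nitrogen. Among the measured compounds shown here, only one measured step concerns the same sulfonamide nitrogen: a 3.3-fold lower number from compound 2 to compound 3 (0.52 log units; beyond the scatter). That step shows that the group attached to this nitrogen shifts the number by a modest amount, and that the six-membered ring with two methyls gave the lower number. For the measured compounds named here, a thiazol-2-yl ring is smaller than the 4,6-dimethylpyrimidin-2-yl it replaces, and no measured pair shows this exact exchange, so the size can only be guessed by analogy with the step from compound 2 to compound 3.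

For compound 4 a modest rise is expected in this assay, a 2.1-fold higher number from compound 3 to compound 4 (0.32 log units; beyond the scatter), about the size of that earlier step but in the opposite direction. Compound 4 is therefore estimated at 16 nM, with a likely range from 5 nM to 50 nM.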

Compound 4, half-maximal inhibitory concentration: 45 nM
Compound 4: middle estimate off by 2.8-fold (0.45 log units), on the low side; the measured number falls inside the stated range.
By their numbers in this assay, from the lowest: compounds 1 and 3 (each within the scatter of the next); then compounds 2 and 4 (each within the scatter of the next).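

In this assay, the step from 4,6-dimethylpyrimidin-2-yl to 1,3-thiazol-2-yl on the sulfonamide nitrogen is a 5.9-fold higher number from compound 3 to compound 4 (0.77 log units; beyond the scatter), so the number at this position can move up as well as down. Set against pyridin-2-yl, the same thiazole ring gives a 1.8-fold higher number from compound 2 to compound 4 (0.26 log units; within the scatter), which means these two groups cannot be ranked, and of the three rings on this nitrogen only 4,6-dimethylpyrimidin-2-yl stands apart with a lower number. Ring size alone does not sort them, as the six-membered ring of compound 2 groups with the five-membered ring of compound 4 rather than with the six-membered ring of compound 3, and nothing available explains why these groups differ.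

The compounds shown leave open whether the lower number of compound 3 goes with its two methyl groups or with the pyrimidine ring itself, a question that a plain pyrimidin-2-yl on this nitrogen would help to settle. They also leave open how the number responds to a group that is not an aromatic ring, such as an acetyl or a short alkyl chain on the same nitrogen.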